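Ring methyl step repeated on a second core

This account rests on a few compounds, and the source may have more. Where it says the series, first, only, none or still open, it means among the compounds named here.

Compound 1 `COCn1c(CC(COCc2ccccc2)COCc2ccccc2)cc(=O)[nH]c1=O` and compound 2 `COCn1c(CC(COCc2ccccc2)COCc2ccccc2)c(C)c(=O)[nH]c1=O` share one core. Compound 3 `C[Si](C)(C)CCOCn1c(CC(O)COCc2ccccc2)cc(=O)[nH]c1=O` differs from compound 1 in more than one place, and the difference between the two cores is not broken down here. In a functional assay on SW-620 cells (Homo sapiens) for antiproliferative activity, read by MTT assay, with a stated time of 72 h (a higher number here means a weaker inhibitor, a lower number a stronger inhibitor), compound 1 gives only a limit, > 100000 nM. Compound 2 gives 72100 nM in this assay. The change between them is methyl in place of hydrogen on an aromatic carbon, and it made an at least 1.3-fold lower number from compound 1 to compound 2 (0.14 log units; that floor lies within the scatter). Compound 3 gives only a limit in this assay, > 100000 nM. Worth noting is the limit of > 100000 nM in this assay, at which 2 of the 3 values shown sit.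

Compound 4 `Cc1c(CC(O)COCc2ccccc2)n(COCC[Si](C)(C)C)c(=O)[nH]c1=O` remains to be measured. Its change from compound 3 is methyl in place of hydrogen on an aromatic carbon. This is the same kind of change as that from compound 1 to compound 2, not the same: the surroundings differ in that the methyl now sits meta to a group of 8 heavy atoms, where before it sat meta to a methoxymethyl group (3 heavy atoms).

The expectation rests first on compound 3 standing at a limit, > 100000 nM. It rests second on the small size of an at least 1.3-fold lower number from compound 1 to compound 2 (0.14 log units; that floor lies within the scatter). Compound 4 is therefore expected to give 90000 nM in this assay. The expected range for compound 4 runs from 40000 nM to 200000 nM. Expected, accordingly, is a step of an at least 1.1-fold lower number from compound 3 to compound 4 (0.04 log units; that floor lies within the scatter), with a fair chance that only a limit is reported again.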

Compound 4, half-maximal inhibitory concentration: > 100000 nM
Compound 4: no number, only a limit (the forecaster's own chance of this, stated with the estimate: 55%); middle value at least 1.1-fold (0.04 log units) away from the limit.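

Compound 4 gives only a limit in this assay, > 100000 nM. Compound 3 also stands at a limit, so no step can be read between the two, and the series stays at the same ceiling: the limit of > 100000 nM in this assay, at which 3 of the 4 values shown sit.

The compounds shown leave open whether methyl in place of hydrogen on an aromatic carbon changes the read-out at all on the core of compound 3.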